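Demethoxylation step across two cores in neutrophil assay

The compounds below may be only part of what the source reports. "The series", "measured", "known", "first", "only" and "open" are said of these compounds alone.

Compound 1 `COc1cc([C@H]2Oc3c(OC)cc(/C=C/C=O)cc3[C@@H]2CO)cc(OC)c1O`, compound 2 `CC(C)=CCOc1ccc(/C=C/CO)cc1` and compound 3 `COc1cc(/C=C/CO)ccc1OCC=C(C)C` have been measured in a functional assay on cells (Neutrophil, Homo sapiens), with a stated time of 5 min; a lower number here means a stronger inhibitor, a higher number a weaker inhibitor; compound 4 `COc1cc([C@H]2Oc3c(OC)cc(/C=C/C=O)cc3[C@@H]2CO)ccc1O` has not. In this assay compound 1 gives 19300 nM and compound 2 gives 9640 nM. Compound 3 reaches only the limit of the assay, > 100000 nM, and no number (the limit of > 100000 nM in this assay, at which 1 of the 3 values shown sits). The change from compound 3 to compound 2 is hydrogen in place of methoxy on an aromatic carbon, and the step is an at least 10-fold lower number from compound 3 to compound 2 (1.01 log units; beyond the scatter). The change from compound 1 to compound 4 is hydrogen in place of methoxy on an aromatic carbon, the same kind of change but not the same, since the surroundings differ: ortho to a hydroxy group rather than to a (3-methylbut-2-en-1-yl)oxy group, and meta to a large group and to a methoxy group rather than to a 3-hydroxyprop-1-en-1-yl group. The difference between the two cores is not broken down here. Resting on that single measured step, a lower number for compound 4 is expected, with a 4.3-fold lower number from compound 1 to compound 4 (0.63 log units; beyond the scatter) set beside an at least 10-fold lower number from compound 3 to compound 2 (1.01 log units; beyond the scatter). Compound 4 is expected at 4500 nM, between 1000 nM and 20000 nM.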

Compound 4, half-maximal inhibitory concentration: 31900 nM
Compound 4: the middle estimate sits 7.1-fold (0.85 log units) below what was measured, outside the stated range (above it).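

In this assay, hydrogen in place of methoxy on the core of compound 1 gives a 1.7-fold higher number from compound 1 to compound 4 (0.22 log units; within the scatter), and the step measured on the other core does not carry over to this core: the same change on two cores in this assay, an at least 10-fold lower number (1.01 log units; beyond the scatter) from compound 3 to compound 2 and a 1.7-fold higher number (0.22 log units; within the scatter) from compound 1 to compound 4, at least 17-fold (1.23 log units) apart, beyond the scatter of two such steps.

Compound 3 is a limit of the assay and not a number: the limit of > 100000 nM in this assay, at which 1 of the 4 values shown sits.

The two pairs show that this change cannot be carried from one core to the other in this series, but they do not show which difference between the cores accounts for the gap, and one pair per core gives no rule.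

As far as these compounds go, it remains open whether an amine or a longer alkoxy chain in place of the methoxy group would shift the number on either core. From the compounds shown here alone, it is also open which of the two pairs a third core would follow.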